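Swapping the Difluorophenyl for a Thiazole: Hepatic Extraction

A few compounds are considered here, and "the series" means these few. Any claim that something is new, unique, unknown or untested is made for them only; others in the source may bear on it.

Of the compounds shown here, two sharing one core have been measured in an ADME assay on liver with Liver microsome (Homo sapiens) as the target, read by LC-MS, using microsomes, with a stated time of 30 min, tested at 1 uM; a lower number here means that the liver removes a smaller share, a higher number that the liver removes a larger share of the compound in one pass. Compound 1 `Cc1cc(-c2ccncc2NC(=O)c2nc(-c3c(F)cccc3F)ccc2N)cc(N)n1` gives 0.96. Compound 2 `Nc1cc(-c2ccncc2NC(=O)c2nc(-c3c(F)cccc3F)ccc2N)nc(C(F)(F)F)n1` gives 0.77, the lower of the two numbers, the step a number 0.19 lower from compound 1 to compound 2 (beyond the scatter) lying beyond the scatter.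

Compound 3 `Nc1cc(-c2ccncc2NC(=O)c2nc(-c3nccs3)ccc2N)nc(C(F)(F)F)n1` has not yet been measured. It differs from compound 2 in one place: 1,3-thiazol-2-yl in place of 2,6-difluorophenyl on an aromatic carbon. Going by the values given here, this change sits on the other end of the shared core from the one altered between compound 1 and compound 2, so no measured step bears directly on it; the single step a number 0.19 lower from compound 1 to compound 2 (beyond the scatter) shows only that a change at one position of this core can move the number by a modest amount, and the scale of the read-out caps the values at unity, leaving more room for a fall than for a rise from where compound 2 stands.

With nothing to steer the direction, compound 3 is expected to give about 0.74 in this assay, within the range 0.55 to 0.92, meaning an expected step a number 0.030 lower from compound 2 to compound 3 (within the scatter) that may well lie within the scatter.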

Compound 3, hepatic extraction ratio: 0.87
Estimate against measurement, compound 3: 0.13 below; measured number inside the range.
By their numbers in this assay, from the lowest: compounds 2, 3 and 1 (each within the scatter of the next, the first and the last beyond it).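

At this end of the shared core, on an aromatic carbon next to the ring nitrogen, putting 1,3-thiazol-2-yl in place of 2,6-difluorophenyl gives a number 0.10 higher from compound 2 to compound 3 (within the scatter) in this assay. This single pair therefore shows that the position can take a five-membered aromatic ring with 2 hetero atoms and 2 hydrogen-bond acceptors in place of a six-membered aromatic ring of carbon only with none, without a difference in hepatic extraction ratio that stands clear of the usual scatter, whereas the step at the other end of the core, a number 0.19 lower from compound 1 to compound 2 (beyond the scatter), stands clear of it. Nothing among the available measurements explains why the two changes differ in this way.

The compounds shown leave open whether a different group at this position, such as a morpholine, a carboxylic acid or a short alkyl chain, would move the hepatic extraction ratio beyond the scatter. They also leave open whether the exchange of 2,6-difluorophenyl for 1,3-thiazol-2-yl would give a similar step with the other end of the core as it stands in compound 1.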